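A few compounds are considered here, and "the series" means these few. Any claim that something is new, unique, unknown or untested is made for them only; others in the source may bear on it.

Series of acrylamide-bearing anilinopyrimidines, all in a functional assay on Raji cells (Homo sapiens) for antiproliferative activity, read by CCK-8 assay, with a stated time of 48 h; on this read-out higher numbers stand for weaker inhibition and lower numbers for stronger inhibition. Compound 1 `C=CC(=O)Nc1cccc(-n2cnc3cnc(Nc4ccc(N5CCN(S(C)(=O)=O)CC5)cc4OC)nc32)c1` gives 21900 nM in this assay. Compound 2 `C=CC(=O)Nc1cccc(-n2cnc3cnc(Nc4ccc(N5CCN(C)CC5)cc4)nc32)c1` gives 7550 nM in this assay, the lowest of the two numbers; the nearest is compound 1, whose number stands beyond the scatter higher. Both numbers lie in the weak range for this read-out.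

Compound 3 `C=CC(=O)Nc1cccc(-n2cnc3cnc(Nc4ccc(N5CCN(S(C)(=O)=O)CC5)cc4)nc32)c1` has not been measured in this assay. It differs from compound 2 by methylsulfonyl in place of methyl on an amine nitrogen in a ring; cut one bond further out, the difference reads 4-methylpiperazin-1-yl to 4-(methylsulfonyl)piperazin-1-yl.

Within the data shown here, no measured pair in the set isolates this change, so the direction of the step has to be an expectation rather than a reading. Among the measured compounds shown here, the only other compound bearing a methylsulfonyl on the ring nitrogen, compound 1, gives the higher number, but it is not a single-change neighbour of either compound 2 or compound 3. The step from compound 2 to compound 3 is expected to be modest and toward a higher number, around a 1.6-fold higher number from compound 2 to compound 3 (0.20 log units; within the scatter), with the edge of the scatter as a real possibility. Compound 3 is estimated at 12000 nM, with a range from 5000 nM to 30000 nM.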

Compound 3, half-maximal inhibitory concentration: > 40000 nM
Compound 3 was reported as a limit; the forecaster's own chance of this, stated with the estimate: 5%; middle value at least 3.3-fold (0.52 log units) away from the limit.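

The value of compound 3 in this assay is a limit of the assay and not a number: the limit of > 40000 nM in this assay, at which 1 of the 3 values shown sits.

Among these compounds, on the amine nitrogen in a ring, this is the first single change that can be read: methylsulfonyl in place of methyl gives an at least 5.2-fold higher number from compound 2 to compound 3 (0.72 log units; beyond the scatter), which places 4-(methylsulfonyl)piperazin-1-yl on the weaker side of 4-methylpiperazin-1-yl, and the real size of the step may be larger still. Among the compounds shown here, the methoxy position can also be read for the first time, but less firmly: hydrogen in place of methoxy on an aromatic carbon gives an at least 1.8-fold higher number from compound 1 to compound 3 (0.26 log units; that floor lies within the scatter), so with methylsulfonyl on the ring nitrogen, the limit supports no firm statement about the methoxy group.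

On these data alone, it remains open whether the weaker result belongs to methylsulfonyl itself or would follow other replacements of methyl on the ring nitrogen, such as a hydrogen, an acetyl group or a longer alkyl chain. As far as these compounds go, it also remains open how a methoxy group on the aromatic carbon would behave with 4-methylpiperazin-1-yl in place, where the read-out still gives a number rather than a limit.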